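Two Inactive Pyrazole Ureas and a Demethylated Analogue

The source may hold more compounds than are shown below. What is called first, only, known or untested is meant among the compounds shown, and "the series" means these compounds.

The data concern three closely related urea compounds tested in a functional assay on HCT-15 cells (Homo sapiens) for inhibition, read by sulforhodamine B assay, with a stated time of 48 h; on this read-out higher numbers stand for lower toxicity in this test and lower numbers for higher toxicity in this test. Compound 1 (`O=C(Nc1cccc(-n2cc(-c3ccncc3)c(-c3ccc(Cl)c(O)c3)n2)c1)Nc1cccc(C(F)(F)F)c1`) gives only a limit in this assay, > 32500 nM. Compound 2 (`COc1cc(-c2nn(-c3cccc(NC(=O)Nc4ccc(Cl)c(Cl)c4)c3)cc2-c2ccncc2)ccc1Cl`) likewise reaches only a limit in this assay, > 50000 nM. Both results therefore stand at the edge of what the test can report, as shown by the limit of > 32500 nM in this assay, at which 1 of the 2 values shown sits, and (the limit of > 50000 nM in this assay, at which 1 of the 2 values shown sits), and neither compound shows measurable toxicity toward these cells within the tested range.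

Compound 3 (`O=C(Nc1cccc(-n2cc(-c3ccncc3)c(-c3ccc(Cl)c(O)c3)n2)c1)Nc1ccc(Cl)c(Cl)c1`) has not yet been measured. It differs from compound 2 by hydrogen in place of methyl on an oxygen on an aromatic ring, so that methoxy becomes hydroxy on the 4-chloro-3-methoxyphenyl group, which becomes 4-chloro-3-hydroxyphenyl. Compound 1 already carries that hydroxy group and still gives only a limit of > 32500 nM. For compound 3 no step beyond the scatter is expected in this assay, so the change from compound 2 to compound 3 is estimated at a number no higher from compound 2 to compound 3 (the limit leaves the size open). Compound 3 is expected to sit around 50000 nM, within 15000 nM to 150000 nM, most likely again reported only as a limit.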

Compound 3, concentration lethal to 50% of the cells: > 32500 nM
Compound 3 ended at the assay's limit; the forecaster's own chance of this, stated with the estimate: 75%; the middle value does not contradict the limit.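

Among these compounds, compound 3, like compound 1 and compound 2, gives only a limit in this assay, so neither the step from compound 2 to compound 3 nor the one from compound 1 to compound 3 can be read. The three compounds leave open whether either change, methoxy to hydroxy or 3-(trifluoromethyl)phenyl to 3,4-dichlorophenyl, alters toxicity toward these cells at all.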